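A few compounds are considered here, and "the series" means these few. Any claim that something is new, unique, unknown or untested is made for them only; others in the source may bear on it.

Measured compounds:
- Compound 1 `CC1=C(C(=O)Nc2ccc(Cl)c(Cl)c2)C(c2cccc(Cl)c2)NC(=O)N1`: 50100 nM
- Compound 2 `CC1=C(C(=O)Nc2ccc(Cl)c(Cl)c2)C(c2ccccc2Cl)NC(=S)N1`: 20000 nM

Both numbers come from a functional assay on PC-3 cells (Homo sapiens) for cytotoxicity, read by sulforhodamine B assay, with a stated time of 48 h; a higher number here means a weaker inhibitor of growth, a lower number a stronger inhibitor of growth. Compound 1 stands highest of the two, that is, it is the weaker growth inhibitor; compound 2 sits at a lower number, and the gap between the two lies beyond the usual scatter. Compound 2 differs from compound 1 in more than one place, so the two values show only where each stands, not what any single change does.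

The step of interest leads to compound 3 `CC1=C(C(=O)Nc2ccc(Cl)c(Cl)c2)C(c2ccccc2O)NC(=O)N1`, which is not yet measured. It differs from compound 1 in one place: 2-hydroxyphenyl in place of 3-chlorophenyl on a saturated ring carbon. Within the data shown here, no measured pair shows this change, so the direction of the step is open. Compound 3 is expected to stay close to compound 1, with a step of a 1.0-fold lower number from compound 1 to compound 3 (0.00 log units; within the scatter) that is not expected to go beyond the scatter. The estimate for compound 3 in this assay is 50000 nM, within a range from 15000 nM to 150000 nM.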

Compound 3, concentration for 50% growth inhibition: 33900 nM
For compound 3 the middle estimate is 1.5-fold (0.17 log units) above the measured one; the measured number falls inside the stated range.
By their numbers in this assay, from the lowest: compounds 2, 3 and 1 (each within the scatter of the next, the first and the last beyond it).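

In this assay, among these compounds, putting 2-hydroxyphenyl in place of 3-chlorophenyl on the saturated ring carbon gives a 1.5-fold lower number from compound 1 to compound 3 (0.17 log units; within the scatter), the first step that changes only this position. This exchange brings in a hydrogen-bond donor and a hydrogen-bond acceptor where the departing group has neither, yet the two compounds stay within the usual scatter of each other, so this position tolerates this particular swap in this cell test. Nothing measured here speaks to what lies behind this result.

The step replaces the chlorine with a hydroxyl and also changes where the substituent sits on the phenyl ring, so the compounds shown cannot separate these two changes. Also open, as far as these compounds go, is how an amine or a carboxylic acid in place of the hydroxyl would read in this assay.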